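The source may hold more compounds than are shown below. What is called first, only, known or untested is meant among the compounds shown, and "the series" means these compounds.

Working notes on the series, read in a functional assay on K562 cells (Homo sapiens) for antiproliferative activity, read by MTT assay; a higher number here means a weaker inhibitor, a lower number a stronger inhibitor. Compound 1 (`CCOC(=O)N1CCCc2cc(S(=O)(=O)N3CC(c4ccccc4)NC3=O)ccc21`) gives > 20000 nM, which is a limit of the assay and not a number. Going by the values given here, compound 2 (`O=C(CCl)N1CCCc2cc(S(=O)(=O)N3CC(c4ccccc4)NC3=O)ccc21`) gives 1100 nM, the only true number so far. Compound 3 (`O=C1NC(c2ccccc2)CN1S(=O)(=O)c1ccc2c(c1)CCCN2C(=O)C(F)(F)F`) gives > 20000 nM, again a limit and not a number. Compound 3 thus stands at the limit of > 20000 nM in this assay, at which 2 of the 3 values shown sit, and a step that the two limits leave unreadable from compound 1 to compound 3 adds nothing further.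

Compound 4 (`O=C(CCl)NC(=O)N1CCCc2cc(S(=O)(=O)N3CC(c4ccccc4)NC3=O)ccc21`) is the next case: ((chloromethyl)carbonyl)amino in place of trifluoromethyl on a carbonyl carbon. Among the compounds with values here, two measured steps bear on it: an at least 18-fold lower number from compound 1 to compound 2 (1.25 log units; beyond the scatter) and an at least 18-fold higher number from compound 2 to compound 3 (1.25 log units; beyond the scatter), both large and beyond the scatter, and both turn on chloromethyl on a carbonyl carbon. Among these three compounds only compound 2 carries chloromethyl and only compound 2 reads as a number; none goes against this, but three compounds are few. Within the data shown here, in compound 4 the chloromethyl returns, but within ((chloromethyl)carbonyl)carbamoyl, a group that no measured compound carries. On the strength of compound 2 at 1100 nM, a large move to a lower number is expected in this assay. A real chance remains that compound 4 stays at the limit of the assay. The expected step is an at least 6.6-fold lower number from compound 3 to compound 4 (0.82 log units; beyond the scatter). For compound 4 the estimate is 3000 nM, with an expected range of 600 nM to 20000 nM.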

Compound 4, half-maximal inhibitory concentration: 515 nM
Compound 4: middle estimate off by 5.8-fold (0.77 log units), on the high side; measured number outside the range, below it.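

In (this assay), the carbonyl carbon whose other neighbour is the amide-type nitrogen in a ring now gives a second readable result, with ((chloromethyl)carbonyl)amino in place of trifluoromethyl (an at least 38-fold lower number from compound 3 to compound 4 (1.58 log units; beyond the scatter)) and in place of ethoxy (an at least 38-fold lower number from compound 1 to compound 4 (1.58 log units; beyond the scatter)), both large steps. Chloromethyl alone is therefore not the only group that gives a number here: ((chloromethyl)carbonyl)amino in its place gives a modest step beyond the scatter (a 2.1-fold lower number from compound 2 to compound 4 (0.33 log units; beyond the scatter)), and among these four compounds the two that carry chloromethyl, compound 2 and compound 4, are the only two that read as numbers, with none going against this. Compound 1 and compound 3 each remain a limit of the assay and not a number: (the limit of > 20000 nM in this assay, at which 2 of the 4 values shown sit)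

The compounds shown do not separate the chlorine from the rest of the group, and a plain methyl, a bromomethyl or an acetylamino group at this carbonyl carbon would bear on that. On these data alone, whether the pattern holds beyond four compounds stays open, as does the reading for an amine or a longer chain in this place.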